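The source may report more compounds than this note shows. Statements on the series, on what has been measured and on what is new or still open speak of the compounds shown alone.

Compound 3 `O=C(CCc1ccc(C(F)(F)F)cc1)Nc1ccc2nc(N3CCC3)ccc2c1` gives the lowest number of the three measured compounds in a functional assay on HEK293 cells for activation of melanin-concentrating hormone receptor 1 (Rattus norvegicus), read by inositol phosphate accumulation (a higher number here means that more compound is needed for the effect, a lower number that less compound is needed), with 56 nM; compound 1 `O=C(CCc1ccc(C(F)(F)F)cc1)Nc1ccc2nc(N3CC4CCC3C4)ccc2c1` gives 150 nM and compound 2 `CC(=O)NC1CCN(c2ccc3cc(NC(=O)CCc4ccc(C(F)(F)F)cc4)ccc3n2)C1` gives 440 nM. Compound 4 `CNC(=O)NC1CCN(c2ccc3cc(NC(=O)CCc4ccc(C(F)(F)F)cc4)ccc3n2)C1` differs from compound 3 in one place: 3-((methylcarbamoyl)amino)pyrrolidin-1-yl in place of azetidin-1-yl on an aromatic carbon. The step that bears most directly on this is a 7.9-fold lower number from compound 2 to compound 3 (0.90 log units; beyond the scatter), where 3-acetamidopyrrolidin-1-yl was replaced by azetidin-1-yl; the present change runs the other way and adds a closely related 3-((methylcarbamoyl)amino)pyrrolidin-1-yl group. The step of a 2.7-fold lower number from compound 1 to compound 3 (0.43 log units; beyond the scatter) points the same way for a larger ring replacing azetidin-1-yl. Compound 4 is therefore expected to give a higher number than compound 3, with an expected step of a 7.1-fold higher number from compound 3 to compound 4 (0.85 log units; beyond the scatter), near compound 2, and is estimated at 400 nM (range 130 nM to 1200 nM).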

Compound 4, half-maximal effective concentration: 30 nM
Compound 4: the middle estimate sits 13-fold (1.12 log units) above what was measured; measured number below the stated range.
By their numbers in this assay, from the lowest: compounds 4 and 3 (each within the scatter of the next); then compound 1; then compound 2.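

With a 1.9-fold lower number from compound 3 to compound 4 (0.27 log units; within the scatter), the 3-((methylcarbamoyl)amino)pyrrolidin-1-yl group stands level with azetidin-1-yl, so a larger group at this place does not by itself raise the number. The decisive change lies at the end of the side chain: methylamino in place of methyl on the carbonyl carbon gives a 15-fold lower number from compound 2 to compound 4 (1.17 log units; beyond the scatter). Replacing the two-ring group gives a 5.0-fold lower number from compound 1 to compound 4 (0.70 log units; beyond the scatter).

Nothing at hand explains the effect of the methylamino group. On these data alone, whether dimethylamino or methoxy on that carbonyl carbon would give a similar number stays open.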